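Working notes: from compound 3 to compound 4

This account rests on a few compounds, and the source may have more. Where it says the series, first, only, none or still open, it means among the compounds named here.

In a functional assay on NIH3T3 cells (Mus musculus) (on this read-out higher numbers stand for an effect only at larger amounts of compound and lower numbers for an effect already at smaller amounts), compound 3 `Cn1cncc1C(OCc1ccc(C#N)cc1C#CCCCCO)c1ccc(C#N)cc1` gives 20.9 nM, within the scatter of compound 2 `CCC/C=C/C=C/c1cc(C#N)ccc1COC(c1ccc(C#N)cc1)c1cncn1C` at 16.7 nM. Compound 1 `Cn1cncc1C(OCc1ccc(C#N)cc1C#Cc1ccccn1)c1ccc(C#N)cc1` gives only a limit, > 0.1 nM.

Compound 4 `Cn1cncc1C(OCc1ccc(C#N)cc1/C=C/c1ccc([N+](=O)[O-])cc1)c1ccc(C#N)cc1` carries 2-(4-nitrophenyl)ethenyl in place of 6-hydroxyhex-1-yn-1-yl on an aromatic carbon.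

Among the measured compounds shown here, the only readable step bearing on this change is a 1.3-fold higher number from compound 2 to compound 3 (0.10 log units; within the scatter), which exchanges hepta-1,3-dien-1-yl for 6-hydroxyhex-1-yn-1-yl at the same place and stays within the scatter. Two further steps, a step that the limit leaves unreadable from compound 1 to compound 2 and a step that the limit leaves unreadable from compound 1 to compound 3, have no readable size. For the measured compounds named here, compound 1 is the only measured compound with an aromatic ring on this side chain, and it offers no number, so the range is kept wide.

In this assay, no shift beyond the scatter is expected, and the expected size is a 1.0-fold lower number from compound 3 to compound 4 (0.02 log units; within the scatter). For compound 4 the estimated value is 20 nM, with an expected range of 5 nM to 80 nM.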

Compound 4, half-maximal effective concentration: 2.24 nM
Compound 4: the middle estimate sits 8.9-fold (0.95 log units) above what was measured, outside the stated range (below it).
By their numbers in this assay, from the lowest: compound 4; then compounds 2 and 3 (each within the scatter of the next).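

At this aromatic carbon, ortho to a large group and meta to a cyano group, 2-(4-nitrophenyl)ethenyl in place of 6-hydroxyhex-1-yn-1-yl gives a 9.3-fold lower number from compound 3 to compound 4 (0.97 log units; beyond the scatter) in this assay. The exchange of pent-1-en-1-yl for 4-nitrophenyl on the double-bonded chain gives a 7.5-fold lower number from compound 2 to compound 4 (0.87 log units; beyond the scatter). Among the compounds shown here, the open-chain groups of compound 2 and compound 3 had stayed within the scatter of each other, so this is the first readable sign that the side chain at this place can move the number, here with a carbon-only aromatic ring and a nitro group in it.

Compound 1 gives only a limit, and no step from it can be read: the limit of > 0.1 nM in this assay, at which 1 of the 4 values shown sits.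

Going by these compounds, whether the ring alone carries the step stays open, as does whether an amine or a carboxylic acid in place of the nitro group would keep the lower number.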